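A few compounds are considered here, and "the series" means these few. Any claim that something is new, unique, unknown or untested is made for them only; others in the source may bear on it.

Measured in a functional assay on HepG2 cells (Homo sapiens) for cytotoxicity, read by MTT assay, with a stated time of 24 h; on this read-out lower numbers stand for stronger inhibition and higher numbers for weaker inhibition:

- compound 1 `CN1C/C(=C\c2ccncc2)C(=O)/C(=C/c2ccccc2F)C1` gives 4600 nM
- compound 2 `CN1C/C(=C\c2ccncc2)C(=O)/C(=C/c2cc([N+](=O)[O-])ccc2F)C1` gives 5200 nM
- compound 3 `CN1C/C(=C\c2ccncc2)C(=O)/C(=C/c2ccccc2C(F)(F)F)C1` gives 3300 nM

Compound 1 cannot be told apart from the other two on these numbers. Adding a nitro group on an aromatic carbon gives a 1.1-fold higher number from compound 1 to compound 2 (0.05 log units; within the scatter), and trifluoromethyl in place of fluoro on an aromatic carbon gives a 1.4-fold lower number from compound 1 to compound 3 (0.14 log units; within the scatter). Both steps are small.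

Compound 4 `Cc1ccc(S(=O)(=O)N2C/C(=C\c3ccncc3)C(=O)/C(=C/c3ccccc3F)C2)cc1` has not yet been measured. It differs from compound 1 by (4-methylphenyl)sulfonyl in place of methyl on an amine nitrogen in a ring, which means (4-methylphenyl)sulfonyl in place of methyl on an amine nitrogen in a ring. Neither measured step touches that nitrogen, so they show only how little the number moved for changes on an aromatic carbon. They give no direction for this much larger change, and any lean toward a lower number is tentative. The expected change is a 1.5-fold lower number from compound 1 to compound 4 (0.19 log units; within the scatter), which may not exceed the scatter. For compound 4 the estimated value is 3000 nM, with an expected range of 1000 nM to 9000 nM.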

Compound 4, half-maximal inhibitory concentration: 9700 nM
For compound 4 the middle estimate is 3.2-fold (0.51 log units) below the measured one; the whole stated range lies below it.
By their numbers in this assay, from the lowest: compounds 3, 1, 2 and 4 (each within the scatter of the next, the first and the last beyond it).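

Within the data shown here, the ring nitrogen is the first place where a change moves the number beyond the scatter: in this assay, (4-methylphenyl)sulfonyl in place of methyl gives a 2.1-fold higher number from compound 1 to compound 4 (0.32 log units; beyond the scatter). The two earlier steps, both on an aromatic carbon, stayed within the scatter, whereas this one shows that the nitrogen substituent can shift the read-out toward weaker inhibition. Even so, the shift is modest for a swap that brings in so many more heavy atoms, and nothing measured here explains it.

The compounds shown leave open whether the sulfonyl link or the 4-methylphenyl ring matters more for this shift. They also leave open what happens with a hydrogen, an acetyl group or a benzyl group on the same nitrogen.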